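The source may report more compounds than this note shows. Statements on the series, on what has been measured and on what is new or still open speak of the compounds shown alone.

Working notes on the amide series. Three members have numbers in an ADME assay for permeability, using PAMPA; on this read-out higher numbers stand for higher permeability and lower numbers for lower permeability. Compound 1 `C=C(C)C(=O)Nc1cccc(-c2nc3ccccc3s2)c1` gives 987 10^-6 cm/s. Compound 2 `O=C(CCl)Nc1cccc(-c2nc3ccccc3s2)c1` gives 660 10^-6 cm/s. Compound 3 `O=C(Nc1cccc(-c2nc3ccccc3s2)c1)c1cccnc1Cl` gives 677 10^-6 cm/s. On these numbers compound 3 is not separable from the other two: a 1.5-fold lower number from compound 1 to compound 3 (0.16 log units; within the scatter) and a 1.0-fold higher number from compound 2 to compound 3 (0.01 log units; within the scatter) are both within the scatter, as is a 1.5-fold lower number from compound 1 to compound 2 (0.17 log units; within the scatter). Every exchange of the group on the carbonyl carbon made so far has stayed within the scatter.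

The next step leads to compound 4 `O=C(Nc1cccc(-c2nc3ccccc3s2)c1)c1ccnc(Cl)c1`, which carries 2-chloropyridin-4-yl in place of 2-chloropyridin-3-yl on a carbonyl carbon. The measured steps that bear on it are the two that brought the departing group in: a 1.0-fold higher number from compound 2 to compound 3 (0.01 log units; within the scatter) and a 1.5-fold lower number from compound 1 to compound 3 (0.16 log units; within the scatter). Neither moved this assay beyond the scatter, although each exchanged one group for a quite different one, whereas the present change keeps the same atoms joined differently. Nothing in the series gives grounds to expect more from it. The expected step is therefore a 1.0-fold higher number from compound 3 to compound 4 (0.00 log units; within the scatter), within the scatter. Compound 4 is estimated at 680 10^-6 cm/s, with a range from 400 10^-6 cm/s to 1100 10^-6 cm/s.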

Compound 4, apparent permeability: 478 10^-6 cm/s
Compound 4: the middle estimate sits 1.4-fold (0.15 log units) above what was measured; the range from low to high includes it.
By their numbers in this assay, from the lowest: compounds 4, 2, 3 and 1 (each within the scatter of the next, the first and the last beyond it).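

In this assay, the exchange of 2-chloropyridin-3-yl for 2-chloropyridin-4-yl on the carbonyl carbon stays within the scatter, with a 1.4-fold lower number from compound 3 to compound 4 (0.15 log units; within the scatter), and so does the exchange of chloromethyl for 2-chloropyridin-4-yl, with a 1.4-fold lower number from compound 2 to compound 4 (0.14 log units; within the scatter). Among these compounds, the new finding is the first step at this position to pass the scatter, a modest one: a 2.1-fold lower number from compound 1 to compound 4 (0.31 log units; beyond the scatter). It holds for this one pair only, since 2-chloropyridin-3-yl, made of the same atoms, stays within the scatter of 1-methylethenyl, and no measurement available here explains the difference between the two chloropyridinyl groups.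

Open, as far as these compounds go, is whether an aminomethyl group, a carboxylic acid or a longer alkyl chain on the carbonyl carbon would give a larger step. Also open, from the compounds shown here alone, is whether the small step seen here would hold with a different shared core.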